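Benzofuran for furan on two related cores: an expectation

The compounds below may be only part of what the source reports. "The series", "measured", "known", "first", "only" and "open" are said of these compounds alone.

Compound 1 `Cc1ncnc2c1c(-c1cc3ccccc3o1)cn2[C@@H]1O[C@H](CO)[C@@H](O)[C@H]1O`: in a functional assay on A549 cells (Homo sapiens), read by MTT assay, with a stated time of 72 h (on this read-out higher numbers stand for weaker inhibition and lower numbers for stronger inhibition), compound 1 gives > 20000 nM, which is a limit of the assay.
Compound 2 `Cc1ncnc2c1c(-c1ccoc1)cn2[C@@H]1O[C@H](CO)[C@@H](O)[C@H]1O`: in this assay compound 2 gives > 20000 nM, again a limit.
Compound 3 `Cc1nc(N)c2c(-c3ccoc3)cn([C@@H]3O[C@H](CO)[C@@H](O)[C@H]3O)c2n1`: in this assay compound 3 gives > 20000 nM, also a limit.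

The change from compound 2 to compound 1 is 1-benzofuran-2-yl in place of furan-3-yl on an aromatic carbon, and it gave a step that the two limits leave unreadable from compound 2 to compound 1. Compound 3 and compound 2 carry different cores; the difference between the two cores is not broken down here. Compound 4 `Cc1nc(N)c2c(-c3cc4ccccc4o3)cn([C@@H]3O[C@H](CO)[C@@H](O)[C@H]3O)c2n1` is not yet measured and arises from compound 3 by 1-benzofuran-2-yl in place of furan-3-yl on an aromatic carbon, the same change that leads from compound 2 to compound 1. For compound 4 in this assay the step is expected to be a step that the limit leaves unreadable from compound 3 to compound 4, an expectation that rests on compound 3 giving only a limit > 20000 nM and on the earlier pair, because the limit of > 20000 nM in this assay, at which 3 of the 3 values shown sit, shows every measured value sitting at that same limit. Compound 4 is therefore estimated at 30000 nM, between 12000 nM and 100000 nM, most likely reported as a limit as well.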

Compound 4, half-maximal inhibitory concentration: > 20000 nM
Compound 4: only a limit was reported; the forecaster's own chance of this, stated with the estimate: 85%; the middle value does not contradict the limit.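

In this assay compound 4 gives > 20000 nM, which is a limit. Within the data shown here, no step from compound 3 to compound 4 can be read, and every compound shares that reading: the limit of > 20000 nM in this assay, at which 4 of the 4 values shown sit. The compounds shown leave open whether 1-benzofuran-2-yl in place of furan-3-yl alters inhibition on either core.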